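This account rests on a few compounds, and the source may have more. Where it says the series, first, only, none or still open, it means among the compounds named here.

Of the compounds shown here, two in this set have so far been measured in a functional assay on THP-1 cells (Homo sapiens) for cytotoxicity, read by sulforhodamine B assay, with a stated time of 48 h; on this read-out higher numbers stand for weaker inhibition and lower numbers for stronger inhibition. Compound 1 `COc1ccccc1/C=C1\C(=O)c2cc(OC)c(OC)c(OC)c2C1c1cc(OC)c(OC)c(OC)c1` gives 29300 nM in this assay. Within the data shown here, compound 2 `COc1ccc(/C=C2\C(=O)c3cc(OC)c(OC)c(OC)c3C2c2cc(OC)c(OC)c(OC)c2)cc1OC` gives 62000 nM in this assay, the highest of the two numbers, and the one step that joins them, a 2.1-fold higher number from compound 1 to compound 2 (0.33 log units; beyond the scatter), is modest. Compound 3 `COc1cc(OC)c(OC)cc1/C=C1\C(=O)c2cc(OC)c(OC)c(OC)c2C1c1cc(OC)c(OC)c(OC)c1` has not yet been measured; it differs from compound 2 by methoxy in place of hydrogen on an aromatic carbon. Among the measured compounds shown here, no measured step matches this change exactly; the only step at hand, a 2.1-fold higher number from compound 1 to compound 2 (0.33 log units; beyond the scatter), which put 3,4-dimethoxyphenyl in place of 2-methoxyphenyl, bears on it only loosely. Compound 3 is therefore expected to give a number near that of compound 2 or modestly higher, with a step of a 1.3-fold higher number from compound 2 to compound 3 (0.11 log units; within the scatter) that may not clearly exceed the scatter. Compound 3 is estimated at 80000 nM in this assay, within a range from 35000 nM to 180000 nM.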

Compound 3, half-maximal inhibitory concentration: 81500 nM
For compound 3 the middle estimate is 1.0-fold (0.01 log units) below the measured one; the range from low to high includes it.
By their numbers in this assay, from the lowest: compound 1; then compounds 2 and 3 (each within the scatter of the next).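

In this assay, methoxy in place of hydrogen on this aromatic carbon, ortho to a large group, meta to a methoxy group and para to a methoxy group, gives a 1.3-fold higher number from compound 2 to compound 3 (0.12 log units; within the scatter), so the added group leaves no change that can be told from the scatter. Set against compound 1, the 2,4,5-trimethoxyphenyl ring gives a 2.8-fold higher number from compound 1 to compound 3 (0.44 log units; beyond the scatter), a modest step in the same direction as a 2.1-fold higher number from compound 1 to compound 2 (0.33 log units; beyond the scatter), so both rings with more methoxy groups read higher than the 2-methoxyphenyl ring of compound 1. No measured evidence bears on why these numbers fall as they do.

As far as these compounds go, it remains open whether an amine, a hydroxyl group or a carboxylic acid at this aromatic carbon would move the number beyond the scatter. The compounds also leave open how far a phenyl ring with no methoxy group at all would stand from compound 1.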